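Adding one methyl to compound 1

The source may report more compounds than this note shows. Statements on the series, on what has been measured and on what is new or still open speak of the compounds shown alone.

In a functional assay on cells (Tumor Cell line, Homo sapiens) for antiproliferative activity (a lower number here means a stronger inhibitor of growth, a higher number a weaker inhibitor of growth), compound 1 (`Cc1ccc2c(O)cc(-c3cccc(Cl)c3)nc2n1`) gives 170 nM. That places it within the scatter of compound 2 (`Cc1cccc(-c2cc(O)c3ccc(C)nc3n2)c1`), at 97.7 nM, and well below compound 3 (`Cc1cc(C)c2c(O)cc(-c3cccc4ccccc34)nc2n1`), at 1050 nM. Compound 4 (`Cc1cc(C)c2c(O)cc(-c3cccc(Cl)c3)nc2n1`) has not yet been measured. It differs from compound 1 by a single change, methyl in place of hydrogen on an aromatic carbon, opposite the ring nitrogen.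

Going by the values given here, the only measured single change is a 1.7-fold lower number from compound 1 to compound 2 (0.24 log units; within the scatter). It lies within the scatter, but it swaps chloro for methyl at a different place, so it bears on this change only loosely. Compound 3 already carries the new methyl and reads 1050 nM, yet it also differs from compound 4 in its other aromatic group, so that high number cannot be credited to the methyl alone. The expected step is therefore small, at a 1.5-fold higher number from compound 1 to compound 4 (0.18 log units; within the scatter), leaning towards a higher number and staying within the scatter. Compound 4 is estimated at 260 nM, with an expected range of 85 nM to 800 nM.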

Compound 4, concentration for 50% growth inhibition: 347 nM
The estimate for compound 4 lay 1.3-fold (0.13 log units) below the measured number, within the range that was stated.
By their numbers in this assay, from the lowest: compounds 2 and 1 (each within the scatter of the next); then compound 4; then compound 3.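

Until now, this carbon opposite the ring nitrogen had no direct reading, since the earlier single change swapped chloro for methyl at a different place. In this assay, adding one methyl here gives a 2.0-fold higher number from compound 1 to compound 4 (0.31 log units; beyond the scatter), so even this small group shifts the number measurably, though only modestly, and growth inhibition is weakened rather than lost. Nothing available gives a reason for this shift.

From the compounds shown here alone, it remains open whether a larger group at this carbon, such as ethyl or a longer chain, would raise the number further, and whether an amine or a methoxy group would behave like methyl. Also open, going by these compounds, is whether the same methyl would produce a similar step when added to compound 2, which carries methyl in place of the chloro.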